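Chloro in place of hydrogen on the aromatic ring

The compounds below may be only part of what the source reports. "The series", "measured", "known", "first", "only" and "open" are said of these compounds alone.

Compound 1 `CC1=CC[C@H](C(C)(C)NC(=S)N/N=C/c2ccccc2)CC1` carries a plain phenyl ring at one end of the shared core. In a functional assay on NCI/ADR-RES cells (Homo sapiens) for inhibition, read by sulforhodamine B assay, with a stated time of 48 h (a higher number here means a weaker inhibitor of growth, a lower number a stronger inhibitor of growth), compound 1 gives > 100000 nM, which is a limit of the assay rather than a number. Among the three measured compounds this is the one case at the limit of > 100000 nM in this assay, at which 1 of the 3 values shown sits, so where compound 1 truly stands is not known beyond that bound.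

Two measured steps change that same ring. Compound 2 `COc1ccc(/C=N/NC(=S)NC(C)(C)[C@H]2CC=C(C)CC2)cc1` gives 43800 nM in this assay, and the step of an at least 2.2-fold lower number from compound 1 to compound 2 (0.35 log units; beyond the scatter). Compound 3 `CC1=CC[C@H](C(C)(C)NC(=S)N/N=C/c2ccc(O)cc2)CC1` gives 82100 nM in this assay, and the step of an at least 1.2-fold lower number from compound 1 to compound 3 (0.08 log units; that floor lies within the scatter). Between them, a 1.9-fold higher number from compound 2 to compound 3 (0.27 log units; within the scatter).

Compound 4 `CC1=CC[C@H](C(C)(C)NC(=S)N/N=C/c2ccccc2Cl)CC1` differs from compound 1 by chloro in place of hydrogen on an aromatic carbon. Neither measured step adds chlorine, so the bearing is indirect: both known substitutions on this ring gave a lower number than compound 1, one of them beyond the scatter, but the scale of change is small. Compound 4 is therefore expected to show an at least 1.4-fold lower number from compound 1 to compound 4 (0.15 log units; that floor lies within the scatter) in this assay. The estimate for compound 4 is 70000 nM, with a range from 25000 nM to 200000 nM.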

Compound 4, concentration for 50% growth inhibition: 75000 nM
Beside the measured number, compound 4's estimate is 1.1-fold (0.03 log units) below it; measured number inside the range.
By their numbers in this assay, from the lowest: compounds 2, 4 and 3 (each within the scatter of the next). At a limit, above all of these: compound 1.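

Compound 4 brings both a new group and a new place on the ring: a chloro ortho to a large group, whereas compound 2 and compound 3 carry 4-methoxyphenyl and 4-hydroxyphenyl. The chloro step reads an at least 1.3-fold lower number from compound 1 to compound 4 (0.12 log units; that floor lies within the scatter), and its true size stays unknown because the starting value is only a limit of the assay: the limit of > 100000 nM in this assay, at which 1 of the 4 values shown sits.

In this assay, the swaps between substituted rings read a 1.1-fold lower number from compound 3 to compound 4 (0.04 log units; within the scatter) and a 1.7-fold higher number from compound 2 to compound 4 (0.23 log units; within the scatter), so these three rings, which differ in both group and place, cannot be told apart by these numbers.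

Going by these compounds, whether chloro would read the same at another place on the ring stays open, and so does whether the group or its place matters more. Also open, on these data alone, is how an amine or a carboxylic acid on this ring would read, and whether any change to this ring can move the number well beyond the narrow band that compound 2, compound 3 and compound 4 share.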